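The compounds below may be only part of what the source reports. "The series", "measured", "known", "first", "only" and "open" are said of these compounds alone.

Measured so far in an ADME assay on Vero cells (Chlorocebus sabaeus) for cytotoxicity, read by neutral red uptake, with a stated time of 48 h; a higher number here means a weaker inhibitor, a lower number a stronger inhibitor:
- Compound 1 `Clc1ccc2c(NCCn3cnc4c(N5CCCC5)nc(Cl)nc43)ccnc2c1`: > 11100 nM
- Compound 2 `Clc1ccc2c(NCCn3cnc4c(N5CCCCCC5)nc(Cl)nc43)ccnc2c1`: > 10400 nM

Neither entry is a true number. Compound 2 reaches only a limit, > 10400 nM. Compound 1 also reaches only a limit, > 11100 nM. The next structure, compound 3 `CN1CCN(c2nc(Cl)nc3c2ncn3CCNc2ccnc3cc(Cl)ccc23)CC1`, carries 4-methylpiperazin-1-yl in place of azepan-1-yl on an aromatic carbon. Among the measured compounds shown here, only one measured step bears on this change, since it also swaps a ring on an aromatic carbon, putting azepan-1-yl in place of pyrrolidin-1-yl. That step is a step that the two limits leave unreadable from compound 1 to compound 2, so it offers no size to carry over. No step beyond the scatter is therefore expected in this assay, and no direction can be given. The expected step is a step that the limit leaves unreadable from compound 2 to compound 3. For compound 3 the estimate is 11000 nM, with an expected range of 4000 nM to 30000 nM, and another limit is the likeliest report.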

Compound 3, half-maximal inhibitory concentration: > 10400 nM
Compound 3: no number, only a limit; the forecaster's own chance of this, stated with the estimate: 75%; the middle value lies beyond the limit too.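

Among the compounds shown here, compound 1, compound 2 and compound 3 all reach only a limit in this assay, so no step among them can be read. The compounds shown leave open whether pyrrolidin-1-yl, azepan-1-yl or 4-methylpiperazin-1-yl on the aromatic carbon makes any difference to the true values.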